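This account rests on a few compounds, and the source may have more. Where it says the series, first, only, none or still open, it means among the compounds named here.

In an ADME assay on HepG2 2.2.15 cells (Homo sapiens) for cytotoxicity (on this read-out higher numbers stand for lower toxicity in this test and lower numbers for higher toxicity in this test), compound 1 `Clc1ccc(C(Oc2ccc3cc(Br)ccc3c2)c2cnc(NCC3CCCCC3)s2)cc1` is reported as "not toxic" (no number reported). Compound 2 `CCCCCC(=O)Nc1ncc(C(Oc2ccc3cc(Br)ccc3c2)c2ccc(Cl)cc2)s1` reaches only a limit of this assay, > 50000 nM. Compound 3 `O=C(Nc1ncc(C(Oc2ccc3cc(Br)ccc3c2)c2ccc(Cl)cc2)s1)c1ccc(F)cc1` is likewise recorded as "not toxic" (no number reported) in this assay, with no single number. Of the three values shown, one sits at the limit of > 50000 nM in this assay, at which 1 of the 3 values shown sits, and the other two carry no number, so compound 3 cannot be placed on a numerical scale. Compound 4 `O=C(Nc1ncc(C(Oc2ccc3cc(Br)ccc3c2)c2ccc(Cl)cc2)s1)c1ccc(Br)cc1` differs from compound 3 by bromo in place of fluoro on an aromatic carbon. For the measured compounds named here, with no measured step in this assay to go by, no shift beyond the usual scatter is expected from this change. Compound 4 is therefore expected to give about 80000 nM in this assay, within 30000 nM to 200000 nM, most likely again reported as a limit.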

Compound 4, half-maximal cytotoxic concentration: > 50000 nM
Compound 4: a limit, no number; the forecaster's own chance of this, stated with the estimate: 85%; the middle value lies beyond the limit too.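

For the compounds shown here, no step from compound 2 to compound 4 can be read in this assay because both rest on the same limit: the limit of > 50000 nM in this assay, at which 2 of the 4 values shown sit. The compounds shown leave open at what concentration, if any, each becomes toxic in this assay.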